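Swapping a methoxy tail for phenyl in a phosphonate amide series

A few compounds are considered here, and "the series" means these few. Any claim that something is new, unique, unknown or untested is made for them only; others in the source may bear on it.

Compound 1 `COc1ccc(CCCCOc2ccc(NC(=O)[C@@](C)(N)COP(=O)(O)O)cc2)cc1` has no single number in an assay on isolated protein for displacement of a labelled ligand from sphingosine 1-phosphate receptor 4 (Homo sapiens); on this read-out higher numbers stand for weaker inhibition and lower numbers for stronger inhibition: there compound 1 gives "not determined" (no result reported), so it gives no anchor of its own. A close relative, compound 2 `C[C@](N)(COP(=O)(O)O)C(=O)Nc1ccc(OCCCCC2CCCCC2)cc1`, does: in this assay compound 2 gives 8.3 nM. Compound 3 `C[C@](N)(COP(=O)(O)O)C(=O)Nc1ccc(OCCCCc2ccc(-c3ccccc3)cc2)cc1` differs from compound 1 by phenyl in place of methoxy on an aromatic carbon. Within the data shown here, no measured pair shows this step, so its size is unknown; a modest shift in either direction, or none beyond the usual scatter, seems plausible. Compound 3 is expected to give about 15 nM, with a range from 3 nM to 80 nM.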

Compound 3, half-maximal inhibitory concentration: 24.8 nM
Estimate against measurement, compound 3: 1.7-fold (0.22 log units) below; the measured number falls inside the stated range.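

Compound 1 has no single number to compare, so the step from compound 1 to compound 3 cannot be read. The compounds shown leave open how phenyl compares with methoxy at this position. Nothing further here bears on the result.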